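A few compounds are considered here, and "the series" means these few. Any claim that something is new, unique, unknown or untested is made for them only; others in the source may bear on it.

Of the compounds shown here, three have so far been measured in an ADME assay on HPC cells (Homo sapiens) for cytotoxicity, with a stated time of 24 h; a lower number here means that less compound is tolerated, a higher number that more compound is tolerated. Compound 1 `Cc1ccc(/C=C2\CCC/C(=C\c3cccc([N+](=O)[O-])c3)C2=O)cc1` gives 192000 nM. Compound 2 `COc1ccc(/C=C2\CCC/C(=C\c3cccc([N+](=O)[O-])c3)C2=O)cc1` gives 33000 nM. Compound 3 `Cc1ccc(/C=C2\CCC/C(=C\c3ccc([N+](=O)[O-])cc3)C2=O)cc1` gives 92000 nM, the second highest of the three numbers: above compound 2 and below compound 1, both gaps beyond the usual scatter.

Compound 2 differs from compound 1 in one place only, (methoxy in place of methyl on an aromatic carbon). That single exchange produced a clear downward step, a 5.8-fold lower number from compound 1 to compound 2 (0.76 log units; beyond the scatter), so less of compound 2 is tolerated by the cells than of compound 1.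

Compound 4 `COc1ccc(/C=C2\CCC/C(=C\c3ccc([N+](=O)[O-])cc3)C2=O)cc1` has not yet been measured in this assay. It arises from compound 3 by exactly the same change, (methoxy in place of methyl on an aromatic carbon), at a place described in the same words as before. The two starting points, compound 1 and compound 3, are built from the same atoms joined differently, and the difference between the two cores is not broken down here.

Among the compounds with values here, with only one measured example of this exchange, the expectation for compound 4 leans on it directly. Within the data shown here, the expected step is a 5.8-fold lower number from compound 3 to compound 4 (0.76 log units; beyond the scatter) because a 5.8-fold lower number from compound 1 to compound 2 (0.76 log units; beyond the scatter) is the sole measured instance and the unexamined core difference adds uncertainty. Compound 4 is therefore expected to give about 16000 nM in this assay, most likely falling between 6000 nM and 45000 nM.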

Compound 4, half-maximal cytotoxic concentration: > 400000 nM
Compound 4 gave a limit, no number; the forecaster's own chance of this, stated with the estimate: 5%; middle value at least 25-fold (1.39 log units) from the limit.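

In this assay compound 4 gives > 400000 nM, which is a limit of the assay and not a number. Even with that limit the step can be read, and going from 4-methylphenyl to 4-methoxyphenyl on this second core gives an at least 4.3-fold higher number from compound 3 to compound 4 (0.63 log units; beyond the scatter), so the change did not carry over from one core to the other and its direction reversed: the same change on two cores in this assay, a 5.8-fold lower number (0.76 log units; beyond the scatter) from compound 1 to compound 2 and an at least 4.3-fold higher number (0.63 log units; beyond the scatter) from compound 3 to compound 4, at least 25-fold (1.40 log units) apart, beyond the scatter of two such steps. This shows that, in this series, the effect of the exchange on how much compound the cells tolerate depends on the core it is made on, but it does not show why the two cores respond in opposite ways, how far compound 4 lies past the limit, or which direction a further core would follow.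

The compounds shown leave open whether another group at this place, such as an amine, a carboxylic acid or a longer chain, would behave like the exchange from compound 1 to compound 2 or like the one from compound 3 to compound 4. They also leave open whether the reversal is specific to methyl and methoxy or would appear with other pairs of groups on these two cores.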